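A few compounds are considered here, and "the series" means these few. Any claim that something is new, unique, unknown or untested is made for them only; others in the source may bear on it.

Of the compounds shown here, three of one series have been measured in a physicochemical assay for lipophilicity; on this read-out higher numbers stand for higher lipophilicity and lower numbers for lower lipophilicity. Compound 2 `CCCCCCCCCCCCCCCCCC(=O)N[C@H](C(=O)Nc1ccn([C@H]2O[C@@H](CO)[C@H](O)[C@H]2O)c(=O)n1)C(C)C` gives 0.91. Compound 1 `CCCCCCCCCCCCCCCCCC(=O)N[C@@H](CCCNC(=N)N)C(=O)Nc1ccn([C@H]2O[C@@H](CO)[C@H](O)[C@H]2O)c(=O)n1` gives 0.61 and differs from compound 2 by a group of 7 heavy atoms (4 carbon, 3 nitrogen; no ring) in place of a group of 3 heavy atoms (3 carbon; no ring), on a saturated chain carbon bound to an amide-type nitrogen and a carbonyl carbon; that change made a step of a number 0.30 log units lower from compound 2 to compound 1 (within the scatter). Compound 3 `CCCCCCCCCCCCCC(=O)N[C@H](C(=O)Nc1ccn([C@H]2O[C@@H](CO)[C@H](O)[C@H]2O)c(=O)n1)C(C)C` gives 0.9; its core differs from that of compound 2 by hydrogen in place of butyl on a saturated chain carbon, ten or more bonds along the chain from a carbonyl carbon, a step of a number 0.01 log units lower from compound 2 to compound 3 (within the scatter). Compound 4 `CCCCCCCCCCCCCC(=O)N[C@@H](CCCNC(=N)N)C(=O)Nc1ccn([C@H]2O[C@@H](CO)[C@H](O)[C@H]2O)c(=O)n1` has not yet been measured. It differs from compound 3 by a group of 7 heavy atoms (4 carbon, 3 nitrogen; no ring) in place of a group of 3 heavy atoms (3 carbon; no ring), on a saturated chain carbon bound to an amide-type nitrogen and a carbonyl carbon, the same change that led from compound 2 to compound 1, now made on the core of compound 3. Because that change once gave a number 0.30 log units lower from compound 2 to compound 1 (within the scatter), compound 4 is expected to sit a number 0.30 log units lower from compound 3 to compound 4 (within the scatter). Compound 4 is therefore estimated at 0.6 in this assay, with a range from 0.3 to 0.9.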

Compound 4, partition coefficient: 0.45
For compound 4 the middle estimate is 0.15 log units above the measured one, and the stated range covers the measured number.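

In this assay the change from isopropyl to a group of 7 heavy atoms (4 carbon, 3 nitrogen; no ring) gave a number 0.45 log units lower from compound 3 to compound 4 (beyond the scatter) and, on the other core, a number 0.30 log units lower from compound 2 to compound 1 (within the scatter) and so pointed the same way on both cores, though only the first of these steps lies beyond the scatter. This single pair of cores shows that the direction carried over here, not that the size of the step is fixed or that it would hold on any further core. With this group in place, hydrogen in place of butyl gave a number 0.16 log units lower from compound 1 to compound 4 (within the scatter) and nothing at hand explains any of these steps.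

The compounds shown leave open whether an amine or a carboxylic acid in place of isopropyl would follow the same direction in this assay and how the change would behave on a core with a longer chain.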